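From 3-Nitrophenyl to 4-Nitrophenyl: An Expected Flat Step

This account rests on a few compounds, and the source may have more. Where it says the series, first, only, none or still open, it means among the compounds named here.

Measured so far in an ADME assay on HEK293 cells (Homo sapiens) for cytotoxicity; a higher number here means a weaker inhibitor, a lower number a stronger inhibitor:
- Compound 1 `CCCCCCCCCCCCCCNC(=O)[C@H](CO)/N=C/c1ccccc1Cl`: 94900 nM
- Compound 2 `CCCCCCCCCCCCCCNC(=O)[C@H](CO)/N=C/c1cccc([N+](=O)[O-])c1`: 82700 nM

Among the compounds with values here, compound 2 stands level with the only other measured compound, and the two cannot be ranked. Within the data shown here, the single measured step is a 1.1-fold lower number from compound 1 to compound 2 (0.06 log units; within the scatter). The next compound, compound 3 `CCCCCCCCCCCCCCNC(=O)[C@H](CO)/N=C/c1ccc([N+](=O)[O-])cc1`, differs from compound 2 by one change: 4-nitrophenyl in place of 3-nitrophenyl on a carbon with a double bond to nitrogen. It has 4-nitrophenyl in place of 3-nitrophenyl on a carbon with a double bond to nitrogen, and the atoms are the same but joined differently. Among the measured compounds shown here, no measured step makes this exact exchange. The nearest evidence is the exchange at the same place, where 3-nitrophenyl replaced 2-chlorophenyl, and that step stayed within the scatter. No step beyond the scatter is therefore expected in this assay. The expected change is a 1.0-fold higher number from compound 2 to compound 3 (0.01 log units; within the scatter). For compound 3 the estimated value is 85000 nM, with an expected range of 50000 nM to 140000 nM.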

Compound 3, half-maximal inhibitory concentration: 49500 nM
Estimate against measurement, compound 3: 1.7-fold (0.23 log units) above; measured number outside the range, below it.
By their numbers in this assay, from the lowest: compounds 3, 2 and 1 (each within the scatter of the next).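

In this assay the exchange of 3-nitrophenyl for 4-nitrophenyl on a carbon with a double bond to nitrogen gives a 1.7-fold lower number from compound 2 to compound 3 (0.22 log units; within the scatter) and the exchange of 2-chlorophenyl for 4-nitrophenyl at the same place gives a 1.9-fold lower number from compound 1 to compound 3 (0.28 log units; within the scatter), so the three groups shown at this place still cannot be ranked. This now holds for an exchange in which the atoms stay the same and are only joined differently, as well as for exchanges between different groups. Nothing available bears on what lies behind these numbers.

From the compounds shown here alone, it remains open whether an amine or a carboxylic acid on the phenyl ring at this place would take the number beyond the scatter. The same question stands for a longer chain in place of the one shared by all three compounds.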